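From 1-phenylethyl to butyl on an amine nitrogen

The source may hold more compounds than are shown below. What is called first, only, known or untested is meant among the compounds shown, and "the series" means these compounds.

Of the compounds shown here, three sharing one core have been measured in an ADME assay on L6 cells (Rattus norvegicus) for cytotoxicity; a lower number here means a stronger inhibitor, a higher number a weaker inhibitor. Compound 1 `COc1cc2c(cc1C(C)NC(=O)c1ccccc1)C=CC(C)(C)O2`, with benzoyl on the amine nitrogen, gives 34800 nM. Compound 2 `COc1cc2c(cc1C(C)N[C@H](C)c1ccccc1)C=CC(C)(C)O2`, with 1-phenylethyl there, gives 15900 nM, and with the opposite drawn configuration at that group, compound 3 `COc1cc2c(cc1C(C)N[C@@H](C)c1ccccc1)C=CC(C)(C)O2` gives 16500 nM. These two 1-phenylethyl compounds sit level, with a 1.0-fold higher number from compound 2 to compound 3 (0.02 log units; within the scatter). Both lie under the benzoyl compound, with a 2.2-fold lower number from compound 1 to compound 2 (0.34 log units; beyond the scatter) and a 2.1-fold lower number from compound 1 to compound 3 (0.32 log units; beyond the scatter). Compound 3 therefore stands with compound 2 at the low end of the numbers seen so far.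

The next compound is compound 4 `CCCCNC(C)c1cc2c(cc1OC)OC(C)(C)C=C2`, which has butyl in place of 1-phenylethyl on an amine nitrogen. Among the measured compounds shown here, no measured compound has a group without a ring at this place, so the evidence is indirect. The only measured replacement at this nitrogen was modest, at a 2.1-fold lower number from compound 1 to compound 3 (0.32 log units; beyond the scatter), and the configuration of the 1-phenylethyl group made no difference beyond the scatter, at a 1.0-fold higher number from compound 2 to compound 3 (0.02 log units; within the scatter). On that basis, no large step is expected in this assay, and any shift is expected to be small and upward. The estimate amounts to a 1.2-fold higher number from compound 3 to compound 4 (0.08 log units; within the scatter), which is an expected change within the scatter. Compound 4 is expected at 20000 nM, with an estimated range of 8000 nM to 50000 nM.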

Compound 4, half-maximal inhibitory concentration: 52500 nM
Estimate against measurement, compound 4: 2.6-fold (0.42 log units) below; the measured number lies above the stated range.
By their numbers in this assay, from the lowest: compounds 2 and 3 (each within the scatter of the next); then compounds 1 and 4 (each within the scatter of the next).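

In this assay, the result shows that this nitrogen is not indifferent to what it carries: butyl in place of 1-phenylethyl gives a 3.2-fold higher number from compound 3 to compound 4 (0.50 log units; beyond the scatter) and a 3.3-fold higher number from compound 2 to compound 4 (0.52 log units; beyond the scatter), so both of these steps lie beyond the scatter, unlike the flat pair of 1-phenylethyl compounds. Butyl and benzoyl, by contrast, stand level, with a 1.5-fold higher number from compound 1 to compound 4 (0.18 log units; within the scatter). Among these four compounds, then, the presence of a ring on the group at this nitrogen does not by itself set the number, since the benzoyl compound carries a ring and still sits with the ringless butyl compound, while only the two 1-phenylethyl compounds sit at the low end.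

Going by these compounds, what the 1-phenylethyl group contributes remains open, and a benzyl group, a cyclohexylmethyl group or a longer chain at this nitrogen would help separate the ring from the branched carbon that holds it. The role of configuration at that group also stays unsettled, because the comparison of the two 1-phenylethyl compounds rests on how they are drawn: the fact that one of compounds 2 and 3 is drawn with a defined configuration and the other without, at the place where they differ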